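Phenyl in Place of Methoxy: What Compound 3 Might Give

A few compounds are considered here, and "the series" means these few. Any claim that something is new, unique, unknown or untested is made for them only; others in the source may bear on it.

Compound 1 `COc1ccc(-n2cc(COc3ccc(/C=C/C(C)=O)cc3OC)nn2)cc1`: 21300 nM
Compound 2 `COc1cccc(-n2cc(COc3ccc(/C=C/C(C)=O)cc3OC)nn2)c1`: 29600 nM

In a functional assay on HCT-116 cells (Homo sapiens) for antiproliferative activity, read by MTT assay, with a stated time of 48 h (a lower number here means a stronger inhibitor, a higher number a weaker inhibitor), compound 1 gives 21300 nM, the lowest of the two numbers. Compound 2 gives 29600 nM, and the step of a 1.4-fold higher number from compound 1 to compound 2 (0.14 log units; within the scatter) stays within the scatter. Compound 3 `COc1cc(/C=C/C(C)=O)ccc1OCc1cn(-c2ccc(-c3ccccc3)cc2)nn1` differs from compound 1 by phenyl in place of methoxy on an aromatic carbon. For the measured compounds named here, no measured step bears directly on this change; the only measured step, from compound 1 to compound 2, concerned a methoxy and was within the scatter. Compound 3 is therefore expected to show no step beyond the scatter, a 1.1-fold lower number from compound 1 to compound 3 (0.03 log units; within the scatter), with an estimated 20000 nM in this assay and a range from 6000 nM to 60000 nM.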

Compound 3, half-maximal inhibitory concentration: 65300 nM
Beside the measured number, compound 3's estimate is 3.3-fold (0.51 log units) below it, outside the stated range (above it).
By their numbers in this assay, from the lowest: compounds 1 and 2 (each within the scatter of the next); then compound 3.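

Moving the methoxy between compounds 1 and 2 left the number within the scatter, but exchanging it for phenyl on this aromatic carbon, para to a large group, gives a 3.1-fold higher number from compound 1 to compound 3 (0.49 log units; beyond the scatter) in this assay and so a weaker inhibitor. This position therefore does not tolerate every group equally, at least in this single change. Nothing available explains the step. From the compounds shown here alone, whether an amine, a carboxylic acid or a chlorine here would stay close to compound 1 or behave like phenyl remains open. So does whether a ring other than phenyl would follow the same course.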